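From phenyl to 4-cyanophenyl: notes on compound 3

A few compounds are considered here, and "the series" means these few. Any claim that something is new, unique, unknown or untested is made for them only; others in the source may bear on it.

Going by the values given here, in a functional assay on KB-VIN10 cells (Homo sapiens) for inhibition, with a stated time of 72 h (on this read-out higher numbers stand for weaker inhibition and lower numbers for stronger inhibition), compound 2 (`COc1ccc(S(=O)(=O)N2CCc3cccc(-c4ccccc4)c32)cc1`) gives 107 nM as the lower of the two numbers so far. Compound 1 (`COc1ccc(S(=O)(=O)N2CCc3cccc(-c4ccc(N)cc4)c32)cc1`) gives 262 nM in this assay on the same core. Compound 3 (`COc1ccc(S(=O)(=O)N2CCc3cccc(-c4ccc(C#N)cc4)c32)cc1`) has cyano in place of hydrogen on an aromatic carbon of the phenyl of compound 2, para to a large group (cyano in place of hydrogen on an aromatic carbon). Among the compounds with values here, only one measured step bears on this change, namely a 2.4-fold lower number from compound 1 to compound 2 (0.39 log units; beyond the scatter) with hydrogen in place of amino on an aromatic carbon, a modest step beyond the scatter. Read backwards, this single pair has a group in place of hydrogen going with the higher number. Within the data shown here, no measured compound carries cyano, so the direction is only weakly supported and the range must stay wide. In this assay a modest move to a higher number is expected, estimated as a 1.7-fold higher number from compound 2 to compound 3 (0.23 log units; within the scatter) on this one precedent. For compound 3 the estimated value is 180 nM within an expected range of 70 nM to 450 nM on present data.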

Compound 3, half-maximal inhibitory concentration: 29.2 nM
The estimate for compound 3 lay 6.2-fold (0.79 log units) above the measured number; measured number below the stated range.
By their numbers in this assay, from the lowest: compound 3; then compound 2; then compound 1.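

In this assay, cyano in place of hydrogen on an aromatic carbon, para to a large group, gives a 3.7-fold lower number from compound 2 to compound 3 (0.56 log units; beyond the scatter), so a group in place of hydrogen at this carbon can go with a lower number as well as a higher one. The earlier pair held only amino against hydrogen, with hydrogen the lower number; the direction at this position therefore depends on the group that enters, and amino and cyano go opposite ways from hydrogen. Exchanging one group for the other gives a 9.0-fold lower number from compound 1 to compound 3 (0.95 log units; beyond the scatter), the largest step in this short series, and no measurement is available that accounts for the opposite directions of these two groups.

On these data alone, with only hydrogen, amino and cyano at this carbon, it remains open whether the lower number is particular to the nitrile or extends to other groups, such as trifluoromethyl, a carboxylic acid or a longer chain. Also open, as far as these compounds go, is whether cyano on another carbon of the same ring would go the same way.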